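This account rests on a few compounds, and the source may have more. Where it says the series, first, only, none or still open, it means among the compounds named here.

Series notes. Three compounds have numbers in a functional assay on HCT-116 cells (Homo sapiens) for inhibition, read by CCK-8 assay, with a stated time of 72 h, tested at 8 uM; on this read-out higher numbers stand for more inhibition of growth at the one concentration tested and lower numbers for less inhibition of growth. Compound 1, `Nc1ccccc1NC(=O)c1ccc(CSc2ccc(Br)cc2)cc1`, gives 67.7%, the highest of the three; compound 2, `Nc1ccccc1NC(=O)c1ccc(CSc2ccc(C(F)(F)F)cn2)cc1`, gives 25.8%, and compound 3, `Nc1ccccc1NC(=O)/C=C/c1ccc(CSc2cccc(F)c2)cc1`, gives 3.22%. Both gaps from compound 1 lie beyond the scatter, so compound 1 stands clearly at the top of this small set.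

Compound 4, `CCc1ccc(SCc2ccc(C(=O)Nc3ccccc3N)cc2)cc1`, is not yet measured. It differs from compound 1 by ethyl in place of bromo on an aromatic carbon. Among the measured compounds shown here, no measured pair in this set isolates such a change, so the size of the step in this assay is not anchored by data. The expectation is a step of a number 12.7 percentage points lower from compound 1 to compound 4 (beyond the scatter), a modest loss that may stay within the scatter. Compound 4 is estimated at 55%, with a range of 30% to 75%.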

Compound 4, percent growth inhibition at one concentration: 79.1%
For compound 4 the middle estimate is 24.1 percentage points below the measured one, outside the stated range (above it).
By their numbers in this assay, from the lowest: compound 3; then compound 2; then compound 1; then compound 4.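

At the aromatic carbon para to a large group, bromine is not needed for growth inhibition: in this assay, ethyl in place of bromo gives a number 11.4 percentage points higher from compound 1 to compound 4 (beyond the scatter). Among the compounds shown here, this is the first one-place comparison, and it shows that an all-carbon group at this position can hold the activity of compound 1 and add to it. Nothing at hand accounts for the gain. Open, from the compounds shown here alone, is whether a longer chain such as propyl would extend the step. Going by these compounds, an amine or a carboxylic acid at this position also remains untested here.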